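The compounds below may be only part of what the source reports. "The series", "measured", "known", "first", "only" and "open" are said of these compounds alone.

Compound 3, `CCOC(=O)c1c(N)sc(-c2ccc(C(F)(F)F)cc2)c1-c1cccc(C(F)(F)F)c1`, gives in a functional assay on CHO-K1 cells for agonist activity at adenosine receptor A1 (Homo sapiens), read by GTPgammaS binding (on this read-out lower numbers stand for an effect already at smaller amounts and higher numbers for an effect only at larger amounts of compound), only a limit of the assay, > 10 uM. Compound 1, `CCOC(=O)c1c(N)sc(-c2ccccc2)c1-c1cccc(C(F)(F)F)c1`, also reaches only a limit in this assay, > 10 uM. Compound 2, `CCOC(=O)c1c(N)sc(-c2ccc(Cl)cc2)c1-c1cccc(C(F)(F)F)c1`, gives 6.6 uM. The measured steps run an at least 1.5-fold lower number from compound 1 to compound 2 (0.18 log units; that floor lies within the scatter) and an at least 1.5-fold higher number from compound 2 to compound 3 (0.18 log units; that floor lies within the scatter), while a step that the two limits leave unreadable from compound 1 to compound 3; the two limits are the limit of > 10 uM in this assay, at which 2 of the 3 values shown sit. Compound 4, `CCOC(=O)c1c(N)sc(-c2ccc(-c3ccncc3)cc2)c1-c1cccc(C(F)(F)F)c1`, carries pyridin-4-yl in place of trifluoromethyl on an aromatic carbon. For the measured compounds named here, no measured step covers a pyridin-4-yl at this position; the readable steps there, chloro and trifluoromethyl against hydrogen, all stay within the scatter. For compound 4 a step of a number no higher from compound 3 to compound 4 (the limit leaves the size open) is therefore expected, with a fair chance that this assay again reports only a limit. Compound 4 is estimated at 10 uM, within 3 uM to 30 uM.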

Compound 4, concentration for half-maximal effect: > 10 uM
Compound 4 ended at the assay's limit (the forecaster's own chance of this, stated with the estimate: 55%); the middle value sits exactly at the limit.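

In this assay, a second aromatic ring at this place, para to a large group, gives no number: compound 4 stays at a limit of the assay, > 10 uM. For the compounds shown here, the only readable new step is an at least 1.5-fold higher number from compound 2 to compound 4 (0.18 log units; that floor lies within the scatter). The steps to compound 4 from compound 1 and compound 3 cannot be read, and the limit now holds most of the series: the limit of > 10 uM in this assay, at which 3 of the 4 values shown sit.

Open, on these data alone, is how far beyond the limit compound 1, compound 3 and compound 4 lie. Also open, as far as these compounds go, is whether a plain phenyl or an amine at this place would give a number, and whether the ring nitrogen of pyridin-4-yl matters.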